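One group exchanged on compound 3

A few compounds are considered here, and "the series" means these few. Any claim that something is new, unique, unknown or untested is made for them only; others in the source may bear on it.

Compound 1 (`OC[C@H]1C[C@@H](Cn2cnc3c(-c4ccc(Cl)cc4)ncnc32)c2ccccc21`) gives 8440 nM
Compound 2 (`CC1(C)[C@@H](Cn2cnc3c(Cl)nc(N)nc32)CC[C@@]1(C)CO`) gives 50000 nM
Compound 3 (`COc1ccccc1C(=O)/C=C/c1cc(=O)[nH]c(=O)n1COCCO`) gives 15200 nM

All three numbers come from an ADME assay on L1210/0 cells (Mus musculus) for cytotoxicity, with a stated time of 48 h (on this read-out lower numbers stand for stronger inhibition and higher numbers for weaker inhibition), and, as the structures show, compounds 1 and 2 are built quite differently from compound 3. The number for compound 3 (15200 nM) lies within the usual scatter of the number for compound 1 (8440 nM). Compound 2 stands higher than compound 3, and that gap lies beyond the scatter.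

Compound 4 (`Cc1ccc(C(=O)/C=C/c2cc(=O)[nH]c(=O)n2COCCO)cc1`) has 4-methylphenyl in place of 2-methoxyphenyl on a carbonyl carbon. Going by the values given here, no two measured compounds differ in only one place, so the data do not show how large such an exchange tends to be. Compound 3 (15200 nM) is therefore the only sound starting point, and no step beyond the scatter is expected in this assay, in either direction. The expected change is small (a 1.1-fold lower number from compound 3 to compound 4 (0.04 log units; within the scatter)). For compound 4 the estimated value is (14000 nM), with an expected range (5000 nM to 40000 nM).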

Compound 4, half-maximal inhibitory concentration: 27900 nM
The estimate for compound 4 lay 2.0-fold (0.30 log units) below the measured number; measured number inside the range.
By their numbers in this assay, from the lowest: compounds 1, 3, 4 and 2 (each within the scatter of the next, the first and the last beyond it).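

In this assay, going by these compounds alone, the exchange of 2-methoxyphenyl for 4-methylphenyl on a carbonyl carbon gives a 1.8-fold higher number from compound 3 to compound 4 (0.26 log units; within the scatter) and is the first step that can be read between compounds differing in one place. This position therefore accepts the loss of the oxygen and the hydrogen-bond acceptor of 2-methoxyphenyl, along with the move to a differently placed group, without a step beyond the scatter. Nothing measured here explains the size of this step.

A single exchange cannot show whether the change of group or the change of its place on the ring matters more, or how large a step at this position can become. Unsubstituted phenyl, or a phenyl ring carrying an amine or a carboxylic acid, would test this position further.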